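A few compounds are considered here, and "the series" means these few. Any claim that something is new, unique, unknown or untested is made for them only; others in the source may bear on it.

Compound 1 `Cc1cc(N2CC[C@@H](C)[C@@H](N(C)c3ncnc4[nH]ccc34)C2)n2ncnc2n1`: 57900 nM
Compound 2 `Cc1cc(N2CC[C@@H](C)[C@@H](N(C)c3ncnc4[nH]ccc34)C2)n2nc(SCc3ccc(C(F)(F)F)cc3)nc2n1`: 17300 nM
Compound 3 `CCc1cc(N2CC[C@@H](C)[C@@H](N(C)c3ncnc4[nH]ccc34)C2)n2ncnc2n1`: > 100000 nM

In a toxicity assay on GES1 cells (Homo sapiens) for inhibition, read by MTT assay, with a stated time of 72 h (on this read-out higher numbers stand for weaker inhibition and lower numbers for stronger inhibition), compound 2 gives the lowest of the two numbers, with compound 1 the nearest at 57900 nM. Compound 3 gives only a limit, (the limit of > 100000 nM in this assay, at which 1 of the 3 values shown sits). Among the measured compounds shown here, the one step that touches the sulfanyl substituent, a 3.3-fold lower number from compound 1 to compound 2 (0.52 log units; beyond the scatter), added that group to the bare core. Compound 4 `Cc1cc(N2CC[C@@H](C)[C@@H](N(C)c3ncnc4[nH]ccc34)C2)n2nc(SCc3nc4ccccc4[nH]3)nc2n1` differs from compound 2 by 1H-benzimidazol-2-yl in place of 4-(trifluoromethyl)phenyl on a saturated chain carbon bound to a sulfur. For the measured compounds named here, no measured step swaps one aryl for another on that chain carbon, so the size of the change is not covered by the data, and only a small shift, if any, beyond the scatter is expected. Compound 4 is therefore estimated at 30000 nM, between 10000 nM and 90000 nM, an expected step of a 1.7-fold higher number from compound 2 to compound 4 (0.24 log units; within the scatter).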

Compound 4, half-maximal inhibitory concentration: 40200 nM
Compound 4: the middle estimate sits 1.3-fold (0.13 log units) below what was measured; the range from low to high includes it.
By their numbers in this assay, from the lowest: compound 2; then compounds 4 and 1 (each within the scatter of the next). At a limit, above all of these: compound 3.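

In this assay, the group on the saturated chain carbon bound to a sulfur matters: 1H-benzimidazol-2-yl in place of 4-(trifluoromethyl)phenyl gives a 2.3-fold higher number from compound 2 to compound 4 (0.37 log units; beyond the scatter). Measured against the bare core, ((1H-benzimidazol-2-yl)methyl)sulfanyl leaves only a 1.4-fold lower number from compound 1 to compound 4 (0.16 log units; within the scatter), so the step seen with (4-(trifluoromethyl)benzyl)sulfanyl does not hold for both sulfanyl groups shown. Nothing measured here accounts for this difference.

As far as these compounds go, whether an amine or a carboxylic acid on that chain carbon would shift the number remains open. So does the effect of a longer chain on the sulfur.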